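The source may report more compounds than this note shows. Statements on the series, on what has been measured and on what is new or still open speak of the compounds shown alone.

Measured in a physicochemical assay for solubility, with a stated time of 18 h, at pH 7.4; a lower number here means a less soluble compound, a higher number a more soluble compound:

- Compound 1 `COc1cccc(CNCCCNc2ccnc3cc(-c4ccc(F)cc4)ccc23)c1O`: 32000 nM
- Compound 2 `CCC(CC)c1ccc2c(NCCCNCc3cc(F)ccc3OC)ccnc2c1`: 4200 nM
- Compound 3 `COc1ccc(F)cc1CNCCCNc1ccnc2cc(-c3ccc(F)cc3)ccc12`: 32000 nM

Level with compound 1, compound 3 gives 32000 nM, and the two share the top number of the three. Compound 4 `COc1ccc(F)cc1CNCCCNc1ccnc2cc(Cc3cc(C)cc(C)c3)ccc12` carries 3,5-dimethylbenzyl in place of 4-fluorophenyl on an aromatic carbon.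

Of the two measured steps, no change at the digits printed from compound 1 to compound 3 (within the scatter) concerns a different place in the molecule and says little here. The step that bears on this change is a 7.6-fold higher number from compound 2 to compound 3 (0.88 log units; beyond the scatter), which exchanged a group at the same place. It shows that this position can move the number, and that compound 2, with pentan-3-yl there, reads lower in this assay. For the measured compounds named here, no measured compound carries 3,5-dimethylbenzyl, so this is indirect evidence from a single step. A drop somewhat smaller than that step is therefore expected.

The expected change is a 3.6-fold lower number from compound 3 to compound 4 (0.55 log units; beyond the scatter).

For compound 4 the estimate is 9000 nM, with an expected range from 2500 nM to 32000 nM.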

Compound 4, solubility: 4200 nM
Beside the measured number, compound 4's estimate is 2.1-fold (0.33 log units) above it; the measured number falls inside the stated range.
By their numbers in this assay, from the lowest: compounds 2 and 4 (each within the scatter of the next); then compounds 1 and 3 (each within the scatter of the next).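

In this assay, 3,5-dimethylbenzyl in place of 4-fluorophenyl gives a 7.6-fold lower number from compound 3 to compound 4 (0.88 log units; beyond the scatter), so this position moves the number with a second replacement group as well, and not only with pentan-3-yl. Set against pentan-3-yl, the same group gives no change at the digits printed from compound 2 to compound 4 (within the scatter), so two quite different groups on this aromatic carbon read alike, while both compounds shown with 4-fluorophenyl there, compound 1 and compound 3, carry the higher number. No measurement offered here accounts for this difference.

As far as these compounds go, whether a plain phenyl or a 4-fluorobenzyl at this position would read with compound 3 or with compound 4 stays open, which leaves the fluorine and the methylene link unseparated. From the compounds shown here alone, how a group carrying an amine or a carboxylic acid would read at this place is also open.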